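Changing the Remote Aromatic Substituent in a Deacetylase Inhibitor Series

The compounds below may be only part of what the source reports. "The series", "measured", "known", "first", "only" and "open" are said of these compounds alone.

Three compounds have been measured in an assay on isolated protein for inhibition of histone deacetylase 8 (Homo sapiens), read by spectrophotometry, with a stated time of 60 min; a higher number here means a weaker inhibitor, a lower number a stronger inhibitor:

compound 1 `N#Cc1ccc(-c2ccc(Cn3cccc(O)c3=S)cc2)cc1`: 2080 nM
compound 2 `N#Cc1cccc(-c2ccc(Cn3cccc(O)c3=S)cc2)c1`: 1700 nM
compound 3 `Cc1cccc(-c2ccc(Cn3cccc(O)c3=S)cc2)c1`: 2500 nM

The three share a common core and differ only in the group carried on the outer aromatic ring. The number for compound 1 sits between those of compound 2 and compound 3, and both gaps are within the scatter of this assay. Within the data shown here, the one measured step that exchanges a group on that ring, a 1.5-fold higher number from compound 2 to compound 3 (0.17 log units; within the scatter), is likewise within the scatter, so the data so far give no sign that this ring's substituent moves the read-out.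

Compound 4 `CN(C)c1ccc(-c2ccc(Cn3cccc(O)c3=S)cc2)cc1` is the next member. It differs from compound 1 by dimethylamino in place of cyano on an aromatic carbon. The step from compound 2 to compound 3 bears on it directly, because a 1.5-fold higher number from compound 2 to compound 3 (0.17 log units; within the scatter) shows that swapping one small group for another at this ring left the number unchanged beyond the scatter. Compound 4 is therefore expected to give 2100 nM, with a range from 900 nM to 5000 nM. The expected step is a 1.0-fold higher number from compound 1 to compound 4 (0.00 log units; within the scatter), none beyond the scatter.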

Compound 4, half-maximal inhibitory concentration: 2860 nM
Compound 4: middle estimate off by 1.4-fold (0.13 log units), on the low side, within the range that was stated.
By their numbers in this assay, from the lowest: compounds 2, 1, 3 and 4 (each within the scatter of the next).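

Compound 1 and compound 4 are the one pair shown that exchanges a group at this place, para to a large group, and the change from cyano to dimethylamino gives a 1.4-fold higher number from compound 1 to compound 4 (0.14 log units; within the scatter) in this assay. Replacing the triple-bonded cyano with dimethylamino, which has one more heavy atom and the same count of hydrogen-bond acceptors, therefore leaves the two numbers within the scatter of each other at this place, as the exchange of cyano for methyl had done in the pair measured earlier. Nothing shown here offers an explanation for these numbers.

The compounds shown leave open whether a carboxylic acid or a primary amine at this place would shift the number beyond the scatter. They also leave open what a longer chain such as butoxy, or a hydrogen in place of any group, would do.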